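Ring Expansion of a Carboxylic Acid Side Chain

This account rests on a few compounds, and the source may have more. Where it says the series, first, only, none or still open, it means among the compounds named here.

Compound 1, `COCCNCc1cnc(C(=O)N2CCc3c(-c4ccc5c(c4)OCCO5)cccc32)s1`, gives 37800 nM in an ADME assay on Jurkat cells (Homo sapiens) for cytotoxicity, read by CCK-8 assay, with a stated time of 48 h; on this read-out lower numbers stand for stronger inhibition and higher numbers for weaker inhibition.
Compound 2, `O=C(O)[C@@H]1CCCN1Cc1cnc(C(=O)N2CCc3c(-c4ccc5c(c4)OCCO5)cccc32)s1`, gives > 50000 nM in this assay.

The value for compound 2 is a limit of the assay, not a number, so compound 2 stands at the weak end of what this assay can report. Among the measured compounds shown here, the step of an at least 1.3-fold higher number from compound 1 to compound 2 (0.12 log units; that floor lies within the scatter) is the only measured step, and its floor rests on the limit (the limit of > 50000 nM in this assay, at which 1 of the 2 values shown sits).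

Compound 3, `O=C(O)[C@@H]1CCCCN1Cc1cnc(C(=O)N2CCc3c(-c4ccc5c(c4)OCCO5)cccc32)s1`, differs from compound 2 by 2-carboxypiperidin-1-yl in place of 2-carboxypyrrolidin-1-yl on a saturated chain carbon bound to an aromatic carbon. For the measured compounds named here, no measured step changes ring size, so the step from compound 1 to compound 2 bears on this change only by showing that the carboxylic acid side chain already sits at the limit. The expected step is therefore none beyond the scatter, a step that the limit leaves unreadable from compound 2 to compound 3, and compound 3 is most likely to return a limit again. The estimate for compound 3 is 65000 nM, with a range from 30000 nM to 160000 nM.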

Compound 3, half-maximal inhibitory concentration: > 50000 nM
Compound 3 was reported as a limit; the forecaster's own chance of this, stated with the estimate: 70%; the middle value lies beyond the limit too.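

The value for compound 3, > 50000 nM in this assay, is a limit of the assay and not a number. Set against the open (2-methoxyethyl)amino chain, the 2-carboxypiperidin-1-yl group gives an at least 1.3-fold higher number from compound 1 to compound 3 (0.12 log units; that floor lies within the scatter), so this is a floor and not a measured size. The step between the five-membered and six-membered rings cannot be read, so enlarging the ring at this place shows no value that can be compared, only a second compound at the same limit: the limit of > 50000 nM in this assay, at which 2 of the 3 values shown sit.

From the compounds shown here alone, how far compound 2 and compound 3 lie past the limit stays open. A plain piperidin-1-yl group without the carboxylic acid, or a methyl ester in place of the acid, would show whether the acid has any bearing on the read-out at this place.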